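Swapping a Triazole for Difluoroethyl: A Solubility Outlook

The source may hold more compounds than are shown below. What is called first, only, known or untested is meant among the compounds shown, and "the series" means these compounds.

Compound 1 `O=C(NCCCCc1ccccc1)c1cccc(C2SCC(=O)N2c2cccc(-c3c[nH]nn3)c2)c1` gives 20000 nM in a physicochemical assay for solubility, read by turbidimetry, measured as kinetic solubility, at pH 7.4 (on this read-out lower numbers stand for lower solubility and higher numbers for higher solubility), the lower of the two numbers recorded so far. Compound 2 `COc1ccc(F)cc1N1C(=O)CSC1c1cccc(C(=O)NCCCCn2cccn2)c1` gives 50000 nM in this assay, a gap beyond the usual scatter. Compound 3 `CC(F)(F)c1cccc(N2C(=O)CSC2c2cccc(C(=O)NCCCCc3ccccc3)c2)c1` has not yet been measured. It differs from compound 1 by 1,1-difluoroethyl in place of 1H-1,2,3-triazol-4-yl on an aromatic carbon, placed on an aromatic carbon of a six-membered aromatic ring of carbon only, meta to a large group. For the measured compounds named here, no step between measured compounds matches this change, so the forecast rests on the change itself: compound 3 is expected to show a moderate fall a 2.5-fold lower number from compound 1 to compound 3 (0.40 log units; beyond the scatter) in this assay. The estimate for compound 3 is 8000 nM, with a range from 3000 nM to 25000 nM.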

Compound 3, solubility: 2000 nM
Beside the measured number, compound 3's estimate is 4.0-fold (0.60 log units) above it; the whole stated range lies above it.
By their numbers in this assay, from the lowest: compound 3; then compound 1; then compound 2.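

On an aromatic carbon of a six-membered aromatic ring of carbon only, meta to a large group, 1,1-difluoroethyl in place of 1H-1,2,3-triazol-4-yl gives a 10-fold lower number from compound 1 to compound 3 (1.00 log units; beyond the scatter) in this assay. For the compounds shown here, this is the first comparison here that isolates a single place, and it shows that the number at this position can move beyond the scatter with the rest of the molecule unchanged.

The compounds shown leave open how a carboxylic acid or a primary amine on this aromatic carbon would read in this assay. Nothing available here accounts for the size of this step.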